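Replacing a Fluoro Group with a Methoxyethoxy Chain

The source may hold more compounds than are shown below. What is called first, only, known or untested is meant among the compounds shown, and "the series" means these compounds.

Compound 1 `Cc1ccc2ccc(-c3cccc(OC(F)(F)F)c3)cc2n1`: > 10000 nM
Compound 2 `COc1ccccc1-c1ccc2ccc(C)nc2c1`: 4200 nM
Compound 3 `Cc1ccc2ccc(-c3cc(F)cc(C#N)c3)cc2n1`: 0.8 nM

Three compounds share one core and differ in the six-membered aromatic ring attached to it. In a functional assay on CHO cells for inhibition of metabotropic glutamate receptor 5 (Rattus norvegicus), read by FLIPR and calcium flux (a lower number here means a stronger inhibitor, a higher number a weaker inhibitor), compound 1 gives only a limit of the assay, > 10000 nM, and no number. Compound 2 gives 4200 nM. Among the compounds with values here, compound 3 gives 0.8 nM, the lowest of the two numbers known; the nearest number, that of compound 2, lies far higher, well beyond the scatter. Compound 4 `COCCOc1cc(C#N)cc(-c2ccc3ccc(C)nc3c2)c1` is not yet measured and differs from compound 3 by 2-methoxyethoxy in place of fluoro on an aromatic carbon, meta to a cyano group. Within the data shown here, no measured pair mirrors this change, so the expected step is a modest weakening, a 5.0-fold higher number from compound 3 to compound 4 (0.70 log units; beyond the scatter), not much beyond the scatter. The estimate for compound 4 in this assay is 4 nM, in the range 1 nM to 25 nM.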

Compound 4, half-maximal inhibitory concentration: 82 nM
For compound 4 the middle estimate is 21-fold (1.31 log units) below the measured one, outside the stated range (above it).
By their numbers in this assay, from the lowest: compound 3; then compound 4; then compound 2. At a limit, above all of these: compound 1.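

At this position, meta to a cyano group, the aromatic carbon does not accept every substituent equally: in this assay, 2-methoxyethoxy in place of fluoro gives a 100-fold higher number from compound 3 to compound 4 (2.01 log units; beyond the scatter) and this is a large step. Even so, the longer chain does not abolish inhibition, since compound 4 still gives a measured 82 nM and no limit. Nothing shown here gives a cause for this step. As far as these compounds go, whether a plain methoxy group or a chain ending in an amine would fall closer to fluoro or to 2-methoxyethoxy remains open. A single change also cannot separate the effect of the chain's length from that of its oxygen atoms.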